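The compounds below may be only part of what the source reports. "The series", "measured", "known", "first", "only" and "open" are said of these compounds alone.

Going by the values given here, in an ADME assay on Vero cells (Chlorocebus sabaeus) for cytotoxicity, read by MTT assay, with a stated time of 72 h (on this read-out lower numbers stand for higher toxicity in this test and higher numbers for lower toxicity in this test), three related compounds have numbers so far. Compound 1 (`COc1ccc(/C=C/C(=O)NCCNc2ccnc3cc(Cl)ccc23)cc1`) gives 20600 nM, the highest of the three, so it is the least toxic of them in this test. Compound 2 (`COc1ccc(/C=C/C(=O)NCCNc2ccnc3cc(Cl)ccc23)cc1OC`) gives 5600 nM, and compound 3 (`COc1ccc(/C=C/C(=O)c2ccc(OCC(O)CNCCNc3ccnc4cc(Cl)ccc34)cc2)cc1`) gives 8030 nM.

Compound 4 (`Cc1ccc(/C=C/C(=O)NCCNc2ccnc3cc(Cl)ccc23)cc1`) has not been measured yet. It keeps the core of compound 1 and alters a single group: methyl in place of methoxy on an aromatic carbon. In plain terms, this is methyl in place of methoxy on an aromatic carbon.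

Among the compounds with values here, one measured step bears on this change, and only loosely: a 3.7-fold lower number from compound 1 to compound 2 (0.57 log units; beyond the scatter), a modest move that came with methoxy in place of hydrogen on an aromatic carbon. That step adds a group, whereas compound 4 swaps one, so it gives no direction for the swap. Compound 3 differs from compound 1 in more than one place and offers no clean comparison.

The step to compound 2 does show that a small change of this kind can shift the number, so the expected range stays wide, but no step beyond the scatter is expected. The expected outcome is a 1.1-fold lower number from compound 1 to compound 4 (0.06 log units; within the scatter). For compound 4 the estimated value is 18000 nM, with an expected range of 8000 nM to 40000 nM.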

Compound 4, half-maximal cytotoxic concentration: 4000 nM
The estimate for compound 4 lay 4.5-fold (0.65 log units) above the measured number; the whole stated range lies above it.
By their numbers in this assay, from the lowest: compounds 4, 2 and 3 (each within the scatter of the next); then compound 1.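

In this assay the methoxy group para to a large group proves to be a sensitive place in compound 1: exchanging it for methyl gives a 5.2-fold lower number from compound 1 to compound 4 (0.71 log units; beyond the scatter) and so points to higher toxicity in this test. The exchange is small, as a methoxy group of two heavy atoms with one hydrogen-bond acceptor gives way to a methyl group of one heavy atom with none, yet this small change clearly moves the number. The only earlier single-place comparison added a group, with a 3.7-fold lower number from compound 1 to compound 2 (0.57 log units; beyond the scatter), whereas this one replaces the existing group, so both single changes shown from compound 1 now lower the number.

A bare hydrogen, a hydroxyl group or an ethoxy group at this same place would help to tell whether the number follows the loss of methoxy or the arrival of methyl, and whether any group here can match compound 1. No measurement given here explains why the number moved.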